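Lengthening the methoxy on compound 1

The source may report more compounds than this note shows. Statements on the series, on what has been measured and on what is new or still open speak of the compounds shown alone.

In a functional assay on A549 cells (Homo sapiens) for antiproliferative activity, read by MTT assay, with a stated time of 72 h (on this read-out higher numbers stand for weaker inhibition and lower numbers for stronger inhibition), compound 1 (`COc1ccccc1-c1ncnn1-c1cc(OC)c(OC)c(OC)c1`) gives only a limit of the assay, > 10000 nM. Compound 2 (`COc1cc(-n2ncnc2-c2cccc(F)c2)cc(OC)c1OC`) likewise gives only a limit, > 10000 nM. Compound 3 (`COc1ccc(-c2ncnn2-c2cc(OC)c(OC)c(OC)c2)cc1`) gives 520 nM, and the step of an at least 19-fold lower number from compound 1 to compound 3 (1.28 log units; beyond the scatter) shows how strongly a change of the ring substituent can move the read-out. The step that the two limits leave unreadable from compound 1 to compound 2 cannot be sized, since both values sit at the limit of > 10000 nM in this assay, at which 2 of the 3 values shown sit. Compound 4 (`CCOc1ccccc1-c1ncnn1-c1cc(OC)c(OC)c(OC)c1`) differs from compound 1 by methyl in place of hydrogen on a saturated chain carbon bound to an oxygen on an aromatic ring. Going by the values given here, no measured step touches this position, so none bears directly on the change. The step that the limit leaves unreadable from compound 1 to compound 4 is therefore expected to be small. The estimate for compound 4 is 15000 nM, with an expected range from 4000 nM to 50000 nM.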

Compound 4, half-maximal inhibitory concentration: > 10000 nM
Compound 4: no number, only a limit (the forecaster's own chance of this, stated with the estimate: 80%); the middle value is on the limit's open side.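

Going by these compounds alone, compound 1 and compound 4 each give only a limit, so no step between them can be read: the limit of > 10000 nM in this assay, at which 3 of the 4 values shown sit. On these data alone, how far ethoxy in place of methoxy moves the read-out remains open.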